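Quinazolinone amides: chloro for methyl on the benzamide ring

The compounds below may be only part of what the source reports. "The series", "measured", "known", "first", "only" and "open" are said of these compounds alone.

Measured compounds:
- compound 1, `O=C(Cn1c(=O)c(/C=C\c2ccncc2)nc2ccccc21)Nc1ccc(Cl)c(Cl)c1`: 47600 nM
- compound 2, `Cc1ccc(C(=O)Nc2ccc(Cn3c(=O)c(C)nc4ccccc43)cc2)cc1`: > 100000 nM

In a functional assay on MCF7 cells (Homo sapiens) for inhibition, read by MTT assay, with a stated time of 24 h (on this read-out lower numbers stand for stronger inhibition and higher numbers for weaker inhibition), compound 1 gives 47600 nM. For compound 2 only a limit of this assay is known, > 100000 nM, so its position on the scale is not fixed; the limit is the limit of > 100000 nM in this assay, at which 1 of the 2 values shown sits.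

Compound 3, `Cc1nc2ccccc2n(Cc2ccc(NC(=O)c3ccc(Cl)cc3)cc2)c1=O`, differs from compound 2 by a single exchange: chloro in place of methyl on an aromatic carbon of a six-membered aromatic ring of carbon only, para to a large group. For the measured compounds named here, no measured step of this kind exists, so the size of the step cannot be read from the data. With compound 2 sitting at a limit, a step in either direction that stays within the scatter is the plainest expectation, and the estimated step from compound 2 to compound 3 is a number no higher from compound 2 to compound 3 (the limit leaves the size open). Compound 3 is therefore expected to give about 100000 nM, within 40000 nM to 250000 nM, with a real chance of another limit.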

Compound 3, half-maximal inhibitory concentration: 47600 nM
The estimate for compound 3 lay 2.1-fold (0.32 log units) above the measured number, and the stated range covers the measured number.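

Chloro in place of methyl on this aromatic carbon, para to a large group, is the first change in the series that can be read as a step: in this assay, 4-methylphenyl to 4-chlorophenyl gives an at least 2.1-fold lower number from compound 2 to compound 3 (0.32 log units; beyond the scatter). With this exchange, compound 3 has a measured number, 47600 nM, so the position responds to the change and the pair is not lost at the edge of the scale. The step remains a lower bound, and its true size stays open because compound 2 holds only a limit of the assay: the limit of > 100000 nM in this assay, at which 1 of the 3 values shown sits.

The compounds shown leave open how fluoro, methoxy or an amine would read on the same carbon. They also leave open whether the exchange of methyl for chloro would give a similar step with a longer chain in place of the methyl on the shared core.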